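The source may hold more compounds than are shown below. What is called first, only, known or untested is meant among the compounds shown, and "the series" means these compounds.

Compound 1 `N#Cc1ccc(Nc2nc(Oc3c(Br)cc(Br)cc3Br)c3ccccc3n2)cc1` gives 58000 nM in an ADME assay on MT4 cells (Homo sapiens) for cytotoxicity, read by MTT assay, with a stated time of 4 days; on this read-out lower numbers stand for higher toxicity in this test and higher numbers for lower toxicity in this test.
Compound 2 `N#Cc1ccc(Nc2nc(Oc3ccccc3Cl)c3ccccc3n2)cc1` gives 38000 nM in this assay.
Compound 3 `Cc1cccc(C)c1Oc1nc(Nc2ccc(C#N)cc2)nc2ccccc12` gives 35000 nM in this assay.

The three measured compounds share one core and differ only in the aryl group on the oxygen. Their numbers in this assay sit close together: a 1.5-fold lower number from compound 1 to compound 2 (0.18 log units; within the scatter), a 1.7-fold lower number from compound 1 to compound 3 (0.22 log units; within the scatter) and a 1.1-fold lower number from compound 2 to compound 3 (0.04 log units; within the scatter). Compound 3 therefore stands among three values that cannot be told apart, with compound 2 nearest to it and compound 1 furthest.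

Compound 4 `N#Cc1ccc(Nc2nc(Oc3ccc(Br)cc3)c3ccccc3n2)cc1` continues this series with 4-bromophenyl in place of 2,6-dimethylphenyl on an oxygen on an aromatic ring. Every measured step bears on it, since each also swaps the aryl on that oxygen, and none of them moved the read-out beyond the scatter. On that basis the step from compound 3 to compound 4 is expected to be a 1.1-fold higher number from compound 3 to compound 4 (0.04 log units; within the scatter), that is, no change beyond the scatter in either direction. Compound 4 is thus estimated at 38000 nM in this assay, with a range from 18000 nM to 75000 nM.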

Compound 4, half-maximal cytotoxic concentration: 215000 nM
Estimate against measurement, compound 4: 5.7-fold (0.75 log units) below, outside the stated range (above it).
By their numbers in this assay, from the lowest: compounds 3, 2 and 1 (each within the scatter of the next); then compound 4.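

At this oxygen the aryl group can move the read-out in this assay beyond the scatter, toward lower toxicity in this test: 4-bromophenyl gives a 6.1-fold higher number from compound 3 to compound 4 (0.79 log units; beyond the scatter) and a 5.7-fold higher number from compound 2 to compound 4 (0.75 log units; beyond the scatter). Bromine alone does not set compound 4 apart, since compound 1 also carries bromine as its 2,4,6-tribromophenyl group and the change from that group still gives a 3.7-fold higher number from compound 1 to compound 4 (0.57 log units; beyond the scatter). Among these four compounds, 4-bromophenyl is the one group that stands clear of the others, while the values of compounds 1, 2 and 3 stay within the scatter of one another.

Nothing shown here explains this gap. As far as these compounds go, it also remains open whether an amine or a carboxylic acid in place of the bromine on this phenyl ring would keep the number as high as that of compound 4.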